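Shortening the chain and dropping the terminal hydroxyl

This account rests on a few compounds, and the source may have more. Where it says the series, first, only, none or still open, it means among the compounds named here.

The three measured compounds share one core and differ only in the chain attached through an oxygen on the aromatic ring. In an assay (Cricetulus griseus) for inhibition of aldehyde dehydrogenase, mitochondrial (Homo sapiens) (on this read-out higher numbers stand for weaker inhibition and lower numbers for stronger inhibition), compound 1 `CCCCCCOc1ccc2c(=O)c(-c3ccc(O)cc3)coc2c1` gives 1500 nM, compound 2 `CCOC(=O)CCCCCOc1ccc2c(=O)c(-c3ccc(O)cc3)coc2c1` gives 280 nM, and compound 3 `O=c1c(-c2ccc(O)cc2)coc2cc(OCCCCCCCCCO)ccc12` gives 700 nM. Compound 3 thus stands second highest of the three: its nearest neighbour is compound 1, with the step of a 2.1-fold lower number from compound 1 to compound 3 (0.33 log units; beyond the scatter), and the lowest number belongs to compound 2, with the step of a 2.5-fold higher number from compound 2 to compound 3 (0.40 log units; beyond the scatter).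

Compound 4 `C=CCCCCOc1ccc2c(=O)c(-c3ccc(O)cc3)coc2c1` is unmeasured. Against compound 3 the change is vinyl in place of 5-hydroxypentyl on a saturated chain carbon, four bonds along the chain from an oxygen on an aromatic ring. The step that bears most directly on it is a 2.1-fold lower number from compound 1 to compound 3 (0.33 log units; beyond the scatter), since compound 4 resembles compound 1 with a double bond at the end of the chain and no hydroxyl; compound 2 adds the further observation that a polar end to the chain went with a lower number, as seen in a 5.4-fold lower number from compound 1 to compound 2 (0.73 log units; beyond the scatter). Removing the hydroxyl and shortening the chain is therefore expected to move the number in this assay upward, back toward compound 1, with a step of about a 1.9-fold higher number from compound 3 to compound 4 (0.27 log units; within the scatter). Compound 4 is estimated at 1300 nM, within a range from 500 nM to 3500 nM.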

Compound 4, half-maximal inhibitory concentration: 150 nM
Compound 4: the middle estimate sits 8.7-fold (0.94 log units) above what was measured, outside the stated range (below it).
By their numbers in this assay, from the lowest: compounds 4 and 2 (each within the scatter of the next); then compound 3; then compound 1.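

The largest change in this set comes from the smallest edit: in this assay, vinyl in place of ethyl at the chain end, four bonds along the chain from an oxygen on an aromatic ring, gives a 10-fold lower number from compound 1 to compound 4 (1.00 log units; beyond the scatter). The earlier compounds shown here suggested that an oxygen-bearing chain end went with a lower number, but the entering vinyl has no hydrogen-bond donor or acceptor, and the step of a 4.7-fold lower number from compound 3 to compound 4 (0.67 log units; beyond the scatter) runs against that reading, while the step of a 1.9-fold lower number from compound 2 to compound 4 (0.27 log units; within the scatter) leaves the ester-ended chain and the vinyl-ended chain unresolved within the usual scatter. So a low number at this position does not depend on an oxygen at the end of the chain, and the double bond alone separates a weak compound from one of the two best here, though no measurement available bears on why this is so.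

The compounds shown leave open whether the double bond must sit at the chain end or whether an internal double bond or a terminal alkyne would serve as well. They also leave open how a terminal double bond behaves on a shorter or longer chain, and what an amine or a carboxylic acid at the chain end would do.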